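Indolyl vinyl sulfones: acetyl versus cyano on the chain

The source may hold more compounds than are shown below. What is called first, only, known or untested is meant among the compounds shown, and "the series" means these compounds.

Measured compounds:
- compound 1, `CC(=O)/C(=C\c1c(-c2ccccc2)[nH]c2ccccc12)S(=O)(=O)c1ccccc1`: 1500 nM
- compound 2, `COc1ccc(-c2[nH]c3ccc(OC)cc3c2C=C(C#N)C#N)cc1`: 5800 nM

Both numbers come from a functional assay on IGROV-1 cells (Homo sapiens) for inhibition, read by sulforhodamine B assay, with a stated time of 48 h; on this read-out lower numbers stand for stronger inhibition of growth and higher numbers for weaker inhibition of growth. Compound 1 stands lowest of the two, with compound 2 giving the higher number, a gap that lies beyond the scatter. For the measured compounds named here, the two structures differ in several places at once, so no single step between them can be drawn; their values show only that compound 1 is the stronger of the pair on this read-out.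

The next compound in the series is compound 3, `N#C/C(=C\c1c(-c2ccccc2)[nH]c2ccccc12)S(=O)(=O)c1ccccc1`. It differs from compound 1 in one place: cyano in place of acetyl on a double-bonded chain carbon bound to a double-bonded chain carbon and a sulfonyl sulfur. Going by the values given here, no measured pair shows this exchange on its own, so there is no step to lean on. The sulfonyl, the chain and the shared core are untouched, and compound 1 with its 1500 nM is the only anchor. The expectation is a step from compound 1 to compound 3 that stays within the scatter, a 1.1-fold lower number from compound 1 to compound 3 (0.03 log units; within the scatter), with no direction claimed. Compound 3 is estimated at 1400 nM in this assay, within a range of 450 nM to 4500 nM.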

Compound 3, concentration for 50% growth inhibition: 3300 nM
Compound 3: middle estimate off by 2.4-fold (0.37 log units), on the low side; the range from low to high includes it.
By their numbers in this assay, from the lowest: compound 1; then compounds 3 and 2 (each within the scatter of the next).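

In this assay, for the compounds shown here, the exchange of acetyl for cyano on a double-bonded chain carbon bound to a double-bonded chain carbon and a sulfonyl sulfur gives the first single-place step, a 2.2-fold higher number from compound 1 to compound 3 (0.34 log units; beyond the scatter). This position is therefore not indifferent to the group it carries on this read-out: with the sulfonyl, the chain and the shared core unchanged, acetyl gives the stronger inhibition of growth of the two groups, although the step is only modest. No measurement at hand bears on what lies behind this step.

This single pair leaves open whether the same step would appear on a different core or with a different group on the sulfonyl. Also open, from the compounds shown here alone, is how a carboxylic acid, a methyl ester or a longer ketone chain at this position would read against compound 1 and compound 3, and so whether the carbonyl of the acetyl matters or any group other than cyano would serve as well.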